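Benzyloxy on compound 2: a working estimate

The source may report more compounds than this note shows. Statements on the series, on what has been measured and on what is new or still open speak of the compounds shown alone.

Values in a functional assay on A-427 cells (Homo sapiens) for cytotoxicity, read by colorimetric assay and MTT assay (a higher number here means a weaker inhibitor, a lower number a stronger inhibitor), by compound:
- compound 1 `COc1ccc2cc(-c3ccccc3)c(O)nc2c1` gives 10000 nM
- compound 2 `COc1cc(OC)c2cc(-c3ccccc3)c(O)nc2c1` gives 10000 nM
- compound 3 `COc1ccc(-c2cc3cccc(OC)c3nc2O)cc1` gives 10000 nM

Compound 2 stands level with compounds 1 and 3, and the numbers show no separation among the three. The next compound is compound 4 `COc1cc(OC)c2cc(-c3ccc(OCc4ccccc4)cc3)c(O)nc2c1`, and the change from compound 2 is benzyloxy in place of hydrogen on an aromatic carbon. Going by the values given here, the one measured step that bears on this is no change at the digits printed from compound 1 to compound 2 (within the scatter), a methoxy in place of hydrogen on an aromatic carbon. It lies within the scatter, but it involves a much smaller group. Compound 3 (10000 nM) also carries a methoxy on the ring that takes the new group, and its value matches that of compound 2. Among the compounds with values here, no measured compound carries benzyloxy, so the size of this step is poorly constrained. No step beyond the scatter is expected in this assay, although a lower value remains possible. The expected step is small (a 1.3-fold lower number from compound 2 to compound 4 (0.10 log units; within the scatter)). Compound 4 is estimated at 8000 nM (expected range 2500 nM to 15000 nM).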

Compound 4, half-maximal inhibitory concentration: 10000 nM
Compound 4: middle estimate off by 1.3-fold (0.10 log units), on the low side, within the range that was stated.
By their numbers in this assay, from the lowest: compounds 1, 2, 3 and 4 (each within the scatter of the next).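

In this assay there is no change at the digits printed from compound 2 to compound 4 (within the scatter) with benzyloxy in place of hydrogen on an aromatic carbon, para to a large group. Going by these compounds alone, the only earlier step, no change at the digits printed from compound 1 to compound 2 (within the scatter) with a methoxy, involved a much smaller group. The new step shows that this position accepts a group carrying a six-membered aromatic ring of carbon only, with the value still printed level with that of compound 2. No measured evidence bears on this result.

All four compounds print the same value, so they do not show whether any change at this position can separate compounds in this assay at all. An amine or a carboxylic acid on the same aromatic carbon would test whether the level reading holds beyond the ether groups seen so far.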